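Fluoro on an Aromatic Carbon: What One Step Suggests

This account rests on a few compounds, and the source may have more. Where it says the series, first, only, none or still open, it means among the compounds named here.

Measured compounds:
compound 1, `Cc1cc(-c2nc3cc(F)ccc3o2)ccc1NC(=O)CCl`: 64500 nM
compound 2, `Cc1cc(-c2nc3ccccc3o2)ccc1NC(=O)CN1CCN(CCCN(C)C)CC1`: 22100 nM
compound 3, `Cc1cc(-c2nc3ccccc3o2)ccc1NC(=O)CCl`: 33500 nM

In a functional assay on A549 cells (Homo sapiens) for cytotoxicity, read by MTT assay, with a stated time of 24 h (on this read-out higher numbers stand for weaker inhibition and lower numbers for stronger inhibition), compound 3 gives 33500 nM, and compound 1, which differs from it by fluoro in place of hydrogen on an aromatic carbon, gives 64500 nM; that step is a 1.9-fold higher number from compound 3 to compound 1 (0.28 log units; within the scatter). Compound 2 gives 22100 nM; the difference between the core of compound 2 and the core of compound 3 is not broken down here. Compound 4, `Cc1cc(-c2nc3cc(F)ccc3o2)ccc1NC(=O)CN1CCN(CCCN(C)C)CC1`, is not yet measured. It differs from compound 2 by fluoro in place of hydrogen on an aromatic carbon, the same change as between compound 3 and compound 1, at the same place. If it acts alike, the expected step is a 1.9-fold higher number from compound 2 to compound 4 (0.28 log units; within the scatter), which rests on the measured step of a 1.9-fold higher number from compound 3 to compound 1 (0.28 log units; within the scatter). Compound 4 is therefore expected to give about 42000 nM in this assay, with a likely range from 20000 nM to 90000 nM.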

Compound 4, half-maximal inhibitory concentration: 12200 nM
The estimate for compound 4 lay 3.4-fold (0.54 log units) above the measured number, outside the stated range (below it).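

In this assay, fluoro in place of hydrogen on the aromatic carbon gives a 1.8-fold lower number from compound 2 to compound 4 (0.26 log units; within the scatter), so on this core the number moves the opposite way from the earlier step. Each step is small on its own, but the two do not agree, so the step measured on the core of compound 3 did not carry over to the core of compound 2: the same change on two cores in this assay, a 1.9-fold higher number (0.28 log units; within the scatter) from compound 3 to compound 1 and a 1.8-fold lower number (0.26 log units; within the scatter) from compound 2 to compound 4, 3.5-fold (0.54 log units) apart, beyond the scatter of two such steps This does not show why the two cores differ and, with each step alone within the scatter, it does not show that fluoro by itself raises or lowers the number on either core.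

The compounds shown leave open whether chloro or methoxy in place of fluoro on that carbon would split the same way between these two cores. They also leave open whether a third core would follow either one.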